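Swapping trifluoromethyl for trifluoromethoxy on a substituted aryl

The source may report more compounds than this note shows. Statements on the series, on what has been measured and on what is new or still open speak of the compounds shown alone.

Compound 1 `CC(O)(CSc1cccc(C(F)(F)F)c1)C(=O)Nc1ccc(S(F)(F)(F)(F)F)cc1`: 26200 nM
Compound 2 `CC(O)(CSc1cccc(OC(F)(F)F)c1)C(=O)Nc1ccc(S(F)(F)(F)(F)F)cc1`: 23800 nM
Compound 3 `CC(O)(COc1ccccc1C(F)(F)F)C(=O)Nc1ccc(S(F)(F)(F)(F)F)cc1`: 7100 nM

Of the compounds shown here, three have been tested in a functional assay on DU-145 cells (Homo sapiens) for antiproliferative activity, read by propidium iodide staining, with a stated time of 96 h; a lower number here means a stronger inhibitor, a higher number a weaker inhibitor. Compound 1 and compound 2 share a core and differ in one place: trifluoromethoxy in place of trifluoromethyl on an aromatic carbon. This change gave a 1.1-fold lower number from compound 1 to compound 2 (0.04 log units; within the scatter), so the two values cannot be told apart. Compound 3 gives the lowest number of the three in this assay; compound 2 stands nearest, and compound 1 furthest, both beyond the scatter. How the core of compound 3 differs from that of compound 1 is not broken down here.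

Compound 4 `CC(O)(COc1ccccc1OC(F)(F)F)C(=O)Nc1ccc(S(F)(F)(F)(F)F)cc1` has not yet been measured. It differs from compound 3 in one place: trifluoromethoxy in place of trifluoromethyl on an aromatic carbon. This is the same kind of change as that from compound 1 to compound 2, but not the same: in the earlier pair the place is meta to a large group, whereas here it is ortho to a large group.

The expectation for compound 4 rests on compound 3 giving 7100 nM and on the earlier swap giving a 1.1-fold lower number from compound 1 to compound 2 (0.04 log units; within the scatter), a step within the scatter. On that basis the step from compound 3 to compound 4 is expected to be small, about a 1.1-fold lower number from compound 3 to compound 4 (0.04 log units; within the scatter). Compound 4 is therefore estimated at 6500 nM in this assay, most likely between 2500 nM and 17000 nM.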

Compound 4, half-maximal inhibitory concentration: 16800 nM
Beside the measured number, compound 4's estimate is 2.6-fold (0.41 log units) below it; low and high end bracket the measured number.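

In this assay, trifluoromethoxy in place of trifluoromethyl, ortho to a large group, gave a 2.4-fold higher number from compound 3 to compound 4 (0.37 log units; beyond the scatter), so on this core the swap is a real, though modest, loss of activity. Set beside the same swap on the core of compound 1, where it made no measurable difference, the two results still cannot be told apart: the same change on two cores in this assay, a 1.1-fold lower number (0.04 log units; within the scatter) from compound 1 to compound 2 and a 2.4-fold higher number (0.37 log units; beyond the scatter) from compound 3 to compound 4, 2.6-fold (0.42 log units) apart, within the scatter of two such steps This shows no evidence that the change behaves differently on the two cores, but it does not prove that the change carries over unchanged, since two pairs are few and a real difference of this size could hide inside the scatter.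

The compounds shown leave open whether a group such as methyl, chlorine or nitrile, placed where trifluoromethyl and trifluoromethoxy sit here, would give a lower or a higher number than either of them. They also leave open whether the swap would give a similar step on further cores, for instance one with an amine or a carboxylic acid on the aromatic ring that carries the group being changed.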